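Methoxy addition on compound 3: expected cytotoxicity

The compounds below may be only part of what the source reports. "The series", "measured", "known", "first", "only" and "open" are said of these compounds alone.

Measured so far in a functional assay on HT-29 cells (Homo sapiens) for cytotoxicity, read by MTT assay, with a stated time of 24 h; on this read-out higher numbers stand for weaker inhibition and lower numbers for stronger inhibition:
compound 1 `C#CCOc1c(/C=N/Cc2ccc(S(N)(=O)=O)cc2)cccc1OC` gives 81300 nM
compound 2 `C#CCOc1ccc([N+](=O)[O-])cc1/C=N/Cc1ccc(S(N)(=O)=O)cc1` gives 34800 nM
compound 3 `O=Cc1ccc(OCc2cn(CCCOc3ccc4ccc(=O)oc4c3)nn2)cc1` gives 100000 nM

Compound 3 sits at the highest number of the three. Compound 1 is the nearest to it and the two lie within the usual scatter of each other, so no order between them can be read. Compound 2 is the furthest from compound 3, and that gap lies beyond the scatter. Among the compounds with values here, none of the three pairs differs in a single place, so no single-change step is available from the measured set.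

Compound 4 `COc1cc(C=O)ccc1OCc1cn(CCCOc2ccc3ccc(=O)oc3c2)nn1` is the one-place relative of compound 3. The change is methoxy in place of hydrogen on an aromatic carbon. Within the data shown here, no measured step in this assay covers such a change, and compound 1, which already carries a methoxy group, gives a number in the same weak region as compound 3. The expectation for the step from compound 3 to compound 4 is therefore none beyond the scatter, a 1.1-fold lower number from compound 3 to compound 4 (0.05 log units; within the scatter). Compound 4 is expected to give about 90000 nM in this assay, with a range from 40000 nM to 200000 nM.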

Compound 4, half-maximal inhibitory concentration: 65400 nM
Beside the measured number, compound 4's estimate is 1.4-fold (0.14 log units) above it; the range from low to high includes it.
By their numbers in this assay, from the lowest: compounds 2, 4, 1 and 3 (each within the scatter of the next, the first and the last beyond it).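

In this assay, methoxy in place of hydrogen on the aromatic carbon ortho to a large group and meta to the formyl group gives a 1.5-fold lower number from compound 3 to compound 4 (0.18 log units; within the scatter), a step within the scatter. Within the data shown here, this is the first single-place comparison, and it shows that 4-formylphenyl to 4-formyl-2-methoxyphenyl produces no readable change in the cytotoxicity number at this position. No supporting data bear on this result.

As far as these compounds go, whether this position can move the number at all remains open: a hydroxyl group, an ethoxy group or a fluorine atom in place of the methoxy group would test this. Also open, from the compounds shown here alone, is whether a carboxylic acid or an amine in place of the formyl group would produce a step beyond the scatter, with or without the methoxy group.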